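A few compounds are considered here, and "the series" means these few. Any claim that something is new, unique, unknown or untested is made for them only; others in the source may bear on it.

Measured so far:
Compound 1, `c1cncc(CNCCCCN(C[C@H]2Cc3ccccc3CN2)[C@H]2CCCc3cccnc32)c1`, gives 15.3 nM in a functional assay on cells for antagonist activity at C-X-C chemokine receptor type 4 (Homo sapiens), read by fluorescence and calcium flux, with stated times of 25 min and 90 s; a higher number here means a weaker inhibitor, a lower number a stronger inhibitor.
Compound 2, `c1ccc2c(c1)CN[C@@H](CN(CCCCNC1CCCCC1)[C@H]1CCCc3cccnc31)C2`, gives 75.2 nM in this assay.

Within the data shown here, compound 2 has the highest number of the two measured in this assay; its nearest neighbour is compound 1, and the step of a 4.9-fold higher number from compound 1 to compound 2 (0.69 log units; beyond the scatter) is the only measured step in the set, the change there being cyclohexyl in place of (pyridin-3-yl)methyl on an amine nitrogen.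

Compound 3, `c1ccc2c(c1)CN[C@@H](CN(CCCCNC1CCOCC1)[C@H]1CCCc3cccnc31)C2`, has not yet been measured in this assay. It differs from compound 2 by oxan-4-yl in place of cyclohexyl on an amine nitrogen, so the saturated ring on that amine nitrogen is kept while one carbon in it gives way to an oxygen, bringing one hydrogen-bond acceptor into the group.

Among the measured compounds shown here, the only step that bears on this site is a 4.9-fold higher number from compound 1 to compound 2 (0.69 log units; beyond the scatter), which shows that the group on this amine nitrogen can move the number in this assay well beyond the scatter. For the measured compounds named here, no measured pair, however, shows the exchange of a carbon ring for an oxygen-containing ring directly. The expectation for compound 3 is therefore a small step, a 1.5-fold lower number from compound 2 to compound 3 (0.18 log units; within the scatter), towards a lower number at most, and possibly none beyond the scatter. Compound 3 is estimated to give 50 nM in this assay, within a range of 20 nM to 150 nM.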

Compound 3, half-maximal inhibitory concentration: 29.4 nM
Compound 3: middle estimate off by 1.7-fold (0.23 log units), on the high side; the range from low to high includes it.
By their numbers in this assay, from the lowest: compounds 1 and 3 (each within the scatter of the next); then compound 2.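

In this assay, the exchange of a single ring carbon for oxygen, with the ring size and heavy-atom count unchanged, gives a 2.6-fold lower number from compound 2 to compound 3 (0.41 log units; beyond the scatter), so this position responds to a change far smaller than the swap of whole groups seen earlier. The step of a 1.9-fold higher number from compound 1 to compound 3 (0.28 log units; within the scatter) shows that compound 1 and compound 3 cannot be told apart here, so among these three compounds a saturated ring on this amine nitrogen does not by itself go with the higher number of compound 2, and an aromatic pyridine ring is not needed to reach the level of compound 1. No measurement shown here accounts for either step.

The compounds shown leave open whether the gain belongs to the oxygen as such, or whether piperidin-4-yl, with a ring nitrogen in that place, or the smaller oxetan-3-yl on the same amine nitrogen would read alike. They also leave open whether the exchange of cyclohexyl for oxan-4-yl gives a similar step with a shorter or longer chain than the butyl linker of the shared core.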